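This account rests on a few compounds, and the source may have more. Where it says the series, first, only, none or still open, it means among the compounds named here.

Compounds with measured values:
compound 1, `CCCN(CCC)c1nc(C(C)(C)C)ccc1CNC(=O)C(C)c1ccc(NS(C)(=O)=O)c(F)c1`, 2.5 nM
compound 2, `CCC1CCN(c2nc(C(C)(C)C)ccc2CNC(=O)C(C)c2ccc(NS(C)(=O)=O)c(F)c2)CC1`, 0.1 nM

Both were run in an assay on cells for antagonist activity at transient receptor potential cation channel subfamily V member 1 (Homo sapiens), read by FLIPR and calcium flux, with a stated time of 6 min; a higher number here means a weaker inhibitor, a lower number a stronger inhibitor. Compound 2 gives 0.1 nM, the lowest of the two numbers seen so far; its nearest neighbour is compound 1, which gives 2.5 nM. Within the data shown here, that neighbour is also the only measured step, a 25-fold lower number from compound 1 to compound 2 (1.40 log units; beyond the scatter), where 4-ethylpiperidin-1-yl in place of dipropylamino on an aromatic carbon produced a large move.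

Compound 3, `CCOc1nc(C(C)(C)C)ccc1CNC(=O)C(C)c1ccc(NS(C)(=O)=O)c(F)c1`, has not yet been measured. It differs from compound 2 in one place: ethoxy in place of 4-ethylpiperidin-1-yl on an aromatic carbon, on an aromatic carbon of a six-membered aromatic ring with one nitrogen, next to the ring nitrogen, ortho to a large group and meta to a tert-butyl group.

Among the measured compounds shown here, only the step from compound 1 to compound 2 bears on this change, and it shows that the group at this position moves the number a great deal. Ethoxy is a much smaller group than either amine seen so far, and the ring of compound 2 is lost, so a weaker result than compound 2 is expected: the estimated step is a 200-fold higher number from compound 2 to compound 3 (2.30 log units; beyond the scatter). For compound 3 the expected value in this assay is 20 nM, with a range from 3 nM to 150 nM.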

Compound 3, inhibition constant: 14.8 nM
Compound 3: the middle estimate sits 1.4-fold (0.13 log units) above what was measured; measured number inside the range.
By their numbers in this assay, from the lowest: compound 2; then compound 1; then compound 3.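

In this assay, the earlier pair showed only that one amine could be exchanged for another at this position, whereas ethoxy now brings a group with no ring and no amine nitrogen at the attachment point. Set against the ring amine, ethoxy gives a 150-fold higher number from compound 2 to compound 3 (2.17 log units; beyond the scatter), and set against the open-chain amine it gives a 5.9-fold higher number from compound 1 to compound 3 (0.77 log units; beyond the scatter), so both amines give lower numbers than ethoxy, and the 4-ethylpiperidin-1-yl group, with 8 heavy atoms against 3 for ethoxy, stands furthest from it. Nothing available here explains why the number moves in this way.

The compounds shown leave open whether the higher number of compound 3 goes with the oxygen at the attachment point, with the small size of ethoxy or with the absence of a ring, since all three differ together in this change. A longer ether such as butoxy, a small amine such as dimethylamino and a ring amine without the ethyl branch, such as piperidin-1-yl, would begin to pull these apart.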